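A few compounds are considered here, and "the series" means these few. Any claim that something is new, unique, unknown or untested is made for them only; others in the source may bear on it.

Measured so far:
- compound 1, `O=C(CN1CCNCC1)N1CCC(NS(=O)(=O)c2cc(S(=O)(=O)c3ccccc3)ccc2C(F)(F)F)CC1`, 140 nM
- compound 2, `O=C([C@@H]1CCCN1C(=O)Nc1ccccc1)N1CCC(NS(=O)(=O)c2cc(S(=O)(=O)c3ccccc3)ccc2C(F)(F)F)CC1`, 20 nM

Both compounds share a large common core and were tested in an assay on isolated protein for binding affinity to secreted frizzled-related protein 1 (Homo sapiens), read by fluorescence; a lower number here means a stronger inhibitor, a higher number a weaker inhibitor. Of the two numbers, compound 2 gives the lower one, with 20 nM. Its nearest neighbour is compound 1, whose number is higher by a margin that lies beyond the usual scatter, so compound 2 is the stronger binder of the pair.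

Compound 3, `CC(C)(C)CCN1CCC[C@H]1C(=O)N1CCC(NS(=O)(=O)c2cc(S(=O)(=O)c3ccccc3)ccc2C(F)(F)F)CC1`, has not been measured yet. It differs from compound 2 in one place: 3,3-dimethylbutyl in place of phenylcarbamoyl on an amine nitrogen in a ring. The urea-like phenylcarbamoyl group, which brought one hydrogen-bond donor and one acceptor, is gone, and a plain branched chain sits on the ring nitrogen instead.

Within the data shown here, no step between measured compounds mirrors this change, so there is nothing to lean on directly. What the two measured values show is that compound 1, which also carries an unsubstituted amine nitrogen instead of a carbamoyl group, gives 140 nM, a weaker result than compound 2. Taking that as a loose guide, the expectation is a moderate loss in this assay, a step of about a 3.0-fold higher number from compound 2 to compound 3 (0.48 log units; beyond the scatter). Compound 3 is therefore estimated at 60 nM, in a range from 15 nM to 250 nM.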

Compound 3, half-maximal inhibitory concentration: 30 nM
Beside the measured number, compound 3's estimate is 2.0-fold (0.30 log units) above it, and the stated range covers the measured number.
By their numbers in this assay, from the lowest: compounds 2 and 3 (each within the scatter of the next); then compound 1.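

In this assay, the ring nitrogen of the five-membered non-aromatic ring tolerates a very different group: 3,3-dimethylbutyl in place of phenylcarbamoyl gives a 1.5-fold higher number from compound 2 to compound 3 (0.18 log units; within the scatter). The group that leaves carries a six-membered aromatic ring, a hydrogen-bond donor and a hydrogen-bond acceptor, while the group that enters has none of these, so none of the three is needed for a value in this range in this pair. The change at the carbonyl carbon, 1-(3,3-dimethylbutyl)pyrrolidin-2-yl in place of (piperazin-1-yl)methyl, gives a 4.7-fold lower number from compound 1 to compound 3 (0.67 log units; beyond the scatter), a step that stands clear of the scatter, and no measurement shown here accounts for either step.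

Still open, on these data alone, is how much the size and shape of the chain on this ring nitrogen matter, for example whether a shorter straight chain, a longer chain or a plain methyl group would read the same. As far as these compounds go, it is also open whether a chain ending in an amine or a carboxylic acid, or a ring nitrogen carrying only a hydrogen, would stay in the same range in this assay.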